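This account rests on a few compounds, and the source may have more. Where it says the series, first, only, none or still open, it means among the compounds named here.

Measured so far:
compound 1 `C=CCc1cc(C(C)=O)c(O)cc1OCCCCCCCCCCC#N`, 14%
compound 2 `CCc1cc(C(C)=O)c(O)cc1OCCCC(C)(C)C(=O)O`, 43%

Within the data shown here, in an assay on isolated protein for binding affinity to leukotriene B4 receptor 1 (Homo sapiens), tested at 1 uM (on this read-out higher numbers stand for more inhibition at the one concentration tested (going by the name of the read-out) and lower numbers for less inhibition), compound 1 gives 14%, the lower of the two numbers so far. Compound 2 gives 43%, a number higher by an amount beyond the scatter of repeated runs. Among the measured compounds shown here, the two measured compounds differ in more than one place, so no step between them is recorded; each shows only its own value.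

Compound 3 `C=CCc1cc(C(C)=O)c(O)cc1OCCCCCC(=O)N(C)C` has not yet been measured in this assay. It is reached from compound 1 by a single change: dimethylcarbamoyl in place of 5-cyanopentyl on a saturated chain carbon, five bonds along the chain from an oxygen on an aromatic ring. For the measured compounds named here, no measured pair here shows what this change does on its own. Starting from the low value of compound 1 in this assay, a step of a number 6 percentage points higher from compound 1 to compound 3 (within the scatter) is expected, one that stays within the usual scatter rather than beyond it. Compound 3 is accordingly estimated at 20% in this assay, with a range from 5% to 40%.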

Compound 3, a percentage reported as inhibition, at one concentration (the size of the read-out at that concentration, not a potency): 54%
The estimate for compound 3 lay 34 percentage points below the measured number; the whole stated range lies below it.
By their numbers in this assay, from the lowest: compound 1; then compound 2; then compound 3.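

Working notes on the series: in this assay, the far end of the chain on the core of compound 1 proves sensitive to a single change, since dimethylcarbamoyl in place of 5-cyanopentyl gives a number 40 percentage points higher from compound 1 to compound 3 (beyond the scatter) at this position, on a saturated chain carbon, five bonds along the chain from an oxygen on an aromatic ring. Among these compounds, this is the first single-place step, and it shows that a group of 5 heavy atoms with a carbonyl can replace one of 7 heavy atoms ending in a nitrile with a large gain in this read-out. No measurement at hand accounts for the rise.

Chain length and end group change together here, so their shares stay unseparated; a nitrile on a shorter chain or a dimethylamide on a longer chain would divide them. Also open, on these data alone, is how a primary amide, a carboxylic acid or an amine would compare at the same chain end.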